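The compounds below may be only part of what the source reports. "The series", "measured", "known", "first", "only" and "open" are said of these compounds alone.

Of the compounds shown here, two sharing one core have so far been measured in an assay on isolated protein for displacement of a labelled ligand from tyrosine-protein kinase TEC (Mus musculus), read by fluorescence polarization; on this read-out lower numbers stand for an effect already at smaller amounts and higher numbers for an effect only at larger amounts of compound. Compound 1 `Nc1ccc2cc(Cl)ccc2n1` gives 76000 nM. Compound 2 `COc1ccc2nc(N)ccc2c1` gives 63000 nM. Among the measured compounds shown here, the only step between them is a 1.2-fold lower number from compound 1 to compound 2 (0.08 log units; within the scatter), so the two numbers cannot be told apart. On the numbers shown, compound 2 stands lowest of the two, with compound 1 as its nearest neighbour at a distance within the scatter; no order between them can be read from this.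

Compound 3 `Nc1ccc2cc(F)ccc2n1` has not yet been measured in this assay. It differs from compound 2 by fluoro in place of methoxy on an aromatic carbon. For the measured compounds named here, the one measured step that bears on this change is the one from compound 1 to compound 2, in which a chloro and a methoxy were exchanged on the same aromatic carbon, and it stayed within the scatter. Returning that carbon to a halogen, now fluoro, is therefore expected to give a step of a 1.1-fold higher number from compound 2 to compound 3 (0.05 log units; within the scatter), with no direction beyond the scatter. Compound 3 is thus estimated at 70000 nM in this assay, within a range from 30000 nM to 160000 nM.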

Compound 3, half-maximal effective concentration: 150000 nM
Compound 3: middle estimate off by 2.1-fold (0.33 log units), on the low side, and the stated range covers the measured number.
By their numbers in this assay, from the lowest: compounds 2, 1 and 3 (each within the scatter of the next, the first and the last beyond it).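

In this assay, this aromatic carbon now shows its first change beyond the scatter, though a modest one: fluoro in place of methoxy gives a 2.4-fold higher number from compound 2 to compound 3 (0.38 log units; beyond the scatter). Among the compounds shown here, exchanging one halogen for the other, fluoro in place of chloro, gives a 2.0-fold higher number from compound 1 to compound 3 (0.30 log units; within the scatter), which stays within the scatter, so among the three compounds only the pair carrying methoxy and fluoro can be told apart, while compound 1 cannot be separated from either. Nothing available explains why the exchange of methoxy for fluoro shifts the number at this position.

The compounds shown leave open whether this carbon tolerates a wider range of groups, for instance an amine, a carboxylic acid or a longer chain such as ethoxy, and whether any of these would move the number by more than this modest step. They also leave open whether changes elsewhere on the shared core would have a larger effect on the number than those seen at this carbon.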